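Isopropyl for methyl on the ring carbon: compound 4

A few compounds are considered here, and "the series" means these few. Any claim that something is new, unique, unknown or untested is made for them only; others in the source may bear on it.

Among the measured compounds shown here, compound 2 `CC(=O)O[C@@H]1OC(=O)[C@@](C)(C(C)=O)[C@@H]1C` is the reference point: in a functional assay on DA-3 cells for cytotoxicity against DA-3 cell line (Mus musculus), read by MTT assay (on this read-out higher numbers stand for weaker inhibition and lower numbers for stronger inhibition), compound 2 gives 9000 nM, the only numeric reading in the set. Compound 1 `CC(=O)O[C@@H]1OC(=O)[C@](C)(C(C)=O)[C@@H]1C(C)C` sits at the limit of this assay, > 50000 nM. Compound 3 `CC(=O)O[C@@H]1OC(=O)[C@@](OC(C)=O)(C(C)=O)[C@@H]1C` likewise gives only the limit > 50000 nM in this assay. For the measured compounds named here, the single measured step, an at least 5.5-fold higher number from compound 2 to compound 3 (0.74 log units; beyond the scatter), shows a loss on replacing the methyl there, in keeping with the limit of > 50000 nM in this assay, at which 2 of the 3 values shown sit. Compound 4 `CC(=O)O[C@@H]1OC(=O)[C@@](C)(C(C)=O)[C@@H]1C(C)C` carries isopropyl in place of methyl on a saturated ring carbon. Going by the values given here, no measured step covers this exchange; compound 1 also bears an isopropyl at that carbon and reaches only the limit. A weakening is therefore expected, a 2.8-fold higher number from compound 2 to compound 4 (0.44 log units; beyond the scatter). For compound 4 the estimated value in this assay is 25000 nM, with a range of 9000 nM to 70000 nM.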

Compound 4, half-maximal inhibitory concentration: > 50000 nM
Compound 4: no number, only a limit; the forecaster's own chance of this, stated with the estimate: 40%; middle value at least 2.0-fold (0.30 log units) away from the limit.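

Isopropyl in place of methyl on this saturated ring carbon now has a measured step in this assay, an at least 5.5-fold higher number from compound 2 to compound 4 (0.74 log units; beyond the scatter), and its size is only a bound, since the value of compound 4 is a limit. Among the compounds shown here, this leaves compound 2 as the only compound with a numeric reading: the limit of > 50000 nM in this assay, at which 3 of the 4 values shown sit. The step between compound 1 and compound 4 cannot be read, so any effect of configuration with isopropyl stays unresolved: the fact that compounds 1 and 4 differ only in the configuration as drawn

Open, from the compounds shown here alone, is whether ethyl at this carbon would retain a numeric reading. Also open, going by these compounds, is how an amine or a carboxylic acid there would read.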